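Inverting one ring stereocentre in a peroxide-bearing acid

This account rests on a few compounds, and the source may have more. Where it says the series, first, only, none or still open, it means among the compounds named here.

Of the compounds shown here, three from this series have been tested in a functional assay on ACHN cells (Homo sapiens) for inhibition; on this read-out higher numbers stand for weaker inhibition of growth and lower numbers for stronger inhibition of growth. Compound 1 `C=C1CCCC(C)(C)C1CC[C@]1(C)CC[C@H]([C@@H](C)C(=O)OC)OO1` gives 480 nM in this assay. Compound 2 `C=C1CCC[C@H]2[C@](C)(CC[C@]3(C)CC[C@@H]([C@@H](C)C(=O)O)OO3)[C@@H](C)CC[C@]12C` gives 920 nM in this assay, a number that lies within the usual scatter of the result for compound 1, so the two cannot be ordered. Compound 3 `C=C1CCCC(C)(C)C1CC[C@@]1(C)CC[C@H]([C@@H](C)C(=O)O)OO1` gives 7830 nM in this assay, a higher number than compound 2 and a gap that lies beyond the scatter; compound 2 thus stands second highest of the three numbers. Compound 4 `C=C1CCC[C@H]2[C@](C)(CC[C@]3(C)CC[C@H]([C@@H](C)C(=O)O)OO3)[C@@H](C)CC[C@]12C` has not yet been measured. Its relation to compound 2 is the two compounds have the same atoms and bonds and differ only in configuration as drawn: 1 of 7 stereo elements differ; a stereocentre at a saturated ring carbon is drawn S in compound 2 and R in compound 4. Among the measured compounds shown here, no pair of measured compounds differs in this single way, so the data give no direct guide to the size of such a step. On general grounds a change of configuration at a ring carbon next to the side chain is expected to weaken inhibition somewhat, so the step from compound 2 to compound 4 is estimated as a 2.2-fold higher number from compound 2 to compound 4 (0.34 log units; beyond the scatter). Compound 4 is therefore expected to give about 2000 nM, within a range from 500 nM to 8000 nM.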

Compound 4, concentration for 50% growth inhibition: 1380 nM
The estimate for compound 4 lay 1.4-fold (0.16 log units) above the measured number, within the range that was stated.
By their numbers in this assay, from the lowest: compounds 1, 2 and 4 (each within the scatter of the next, the first and the last beyond it); then compound 3.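

In this assay, inverting this saturated ring carbon from S to R gives a 1.5-fold higher number from compound 2 to compound 4 (0.18 log units; within the scatter). Among the compounds shown here, for this one pair, the configuration at this position therefore makes no difference that can be told from the scatter of repeated measurements, which the earlier compounds could not show, as no two of them differed in a single place. The comparison isolates this one change: the fact that compounds 2 and 4 differ only in the configuration as drawn

The compounds shown leave open whether the inversion would be as small a step with the methyl ester in place of the carboxylic acid, or at any of the other stereocentres. They also leave open how an amide or a primary alcohol in place of the carboxylic acid would read in this assay, with either configuration at this carbon.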